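Removing one fluoro group from compound 1

A few compounds are considered here, and "the series" means these few. Any claim that something is new, unique, unknown or untested is made for them only; others in the source may bear on it.

In a functional assay on CCRF-CEM cells (Homo sapiens) for cytotoxicity, in the absence of a further agent (on this read-out lower numbers stand for stronger inhibition and higher numbers for weaker inhibition), compound 1 (`COC(=O)c1ccc(CN(CCCc2c(N)nc(N)nc2O)c2cc(F)c(F)cc2[N+](=O)[O-])cc1`) gives 59000 nM. Compound 3 (`CC(C)(C)OC(=O)CCC(Nc1ccc(CN(CCCc2c(N)nc(N)nc2O)c2cc(F)cc(F)c2[N+](=O)[O-])cc1)C(=O)OC(C)(C)C`) gives 13000 nM, so compound 1 has the higher of the two actual numbers, by a gap beyond the scatter. However, these two compounds differ in more than one place. Compound 2 (`Nc1nc(N)c(CCCN(Cc2ccc(NC(CCC(=O)O)C(=O)O)cc2)c2cc(F)c(F)cc2[N+](=O)[O-])c(O)n1`) reports > 100000 nM, which is a limit of the assay and not a number.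

Compound 4 (`COC(=O)c1ccc(CN(CCCc2c(N)nc(N)nc2O)c2cc(F)ccc2[N+](=O)[O-])cc1`) is compound 1 with hydrogen in place of fluoro on an aromatic carbon, turning 4,5-difluoro-2-nitrophenyl into 5-fluoro-2-nitrophenyl: hydrogen in place of fluoro on an aromatic carbon. Going by the values given here, the only measured single-place step, an at least 1.6-fold higher number from compound 1 to compound 2 (0.22 log units; that floor lies within the scatter), changes the methoxycarbonyl group and leaves the fluoro groups alone. Among the compounds with values here, it therefore gives no direct guide to this change, and no measured step isolates a fluoro group. With no basis for a direction, the expectation in this assay is no shift beyond the scatter, and the expected step is a 1.0-fold higher number from compound 1 to compound 4 (0.01 log units; within the scatter). The estimate for compound 4 is 60000 nM, with an expected range from 25000 nM to 100000 nM.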

Compound 4, half-maximal inhibitory concentration: 45000 nM
Beside the measured number, compound 4's estimate is 1.3-fold (0.12 log units) above it, within the range that was stated.
By their numbers in this assay, from the lowest: compound 3; then compounds 4 and 1 (each within the scatter of the next). At a limit, above all of these: compound 2.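

In this assay, going by these compounds alone, this is the first step that isolates a fluoro group on the ring, and it reads a 1.3-fold lower number from compound 1 to compound 4 (0.12 log units; within the scatter). Losing the fluoro group that sits ortho to another fluoro group and meta to a nitro group therefore produces no shift that this read-out can separate from the scatter, so 4,5-difluoro-2-nitrophenyl and 5-fluoro-2-nitrophenyl cannot be told apart here. Both compounds give actual numbers, unlike compound 2, which sits at a limit of the assay: the limit of > 100000 nM in this assay, at which 1 of the 4 values shown sits.

On these data alone, whether a chloro, methoxy or amine group at this position would move the number remains open, as does the effect of removing the remaining fluoro group. Also open, as far as these compounds go, is whether the same swap would behave alike with the (1,3-dicarboxypropyl)amino group of compound 2 in place of methoxycarbonyl.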